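This account rests on a few compounds, and the source may have more. Where it says the series, first, only, none or still open, it means among the compounds named here.

Measured compounds:
compound 1, `CCCCCC(C#CC(=O)OC)O/C=C/C(=O)OC`: 1900 nM
compound 2, `COC(=O)/C=C/OC(C#CC(=O)O)C(C)(C)C`: > 100000 nM

In a functional assay on HBL-100 cells (Homo sapiens) for antiproliferative activity, read by sulforhodamine B assay, with a stated time of 48 h (on this read-out lower numbers stand for stronger inhibition of growth and higher numbers for weaker inhibition of growth), compound 1 holds the only number shown, compound 1 giving 1900 nM. Compound 2 gives > 100000 nM, which is the limit of > 100000 nM in this assay, at which 1 of the 2 values shown sits, and not a number. Compound 3, `COC(=O)C#CC(C)O/C=C/C(=O)OC`, is not yet measured. It differs from compound 1 in one place: hydrogen in place of butyl on a saturated chain carbon, two bonds along the chain from an oxygen on an unsaturated carbon and a triple-bonded carbon. Among the measured compounds shown here, no step between two measured compounds is known here, so the size of this change can only be expected: the step of a 3.2-fold higher number from compound 1 to compound 3 (0.50 log units; beyond the scatter) is expected to weaken growth inhibition, beyond the usual scatter. Compound 3 is therefore estimated at 6000 nM, between 2000 nM and 20000 nM.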

Compound 3, concentration for 50% growth inhibition: 300 nM
Estimate against measurement, compound 3: 20-fold (1.30 log units) above, and the stated range ends above it.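

In this assay, hydrogen in place of butyl on this saturated chain carbon gives a 6.3-fold lower number from compound 1 to compound 3 (0.80 log units; beyond the scatter) and so turns a pentyl chain into a methyl. The pentyl chain is therefore not needed for growth inhibition here, and the much smaller methyl does better. Nothing shown here explains why the number falls.

As far as these compounds go, whether an ethyl or propyl chain would lie between these two results remains open. So does the effect of a cyclohexyl ring or an amine at this carbon.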